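The compounds below may be only part of what the source reports. "The series", "measured", "known", "first", "only" and "open" are said of these compounds alone.

Working notes on the dichloroacetamide series.

The series is followed in a functional assay on KB 3-1 cells (Homo sapiens) for cytotoxicity, read by MTT assay, with a stated time of 68 h; a lower number here means a stronger inhibitor, a higher number a weaker inhibitor. Compound 1 `O=C(Nc1cccc(-c2ccc(F)cc2)c1)C(Cl)Cl` gives 26200 nM. Compound 3 `CCOc1cccc(-c2cc(NC(=O)C(Cl)Cl)cc(-c3cccc(OCC)c3)c2)c1` gives 14800 nM; the two numbers sit within the scatter of each other, so no order between compound 1 and compound 3 is read from them. Compound 2 `O=C(Nc1cccc(-c2cccc(F)c2)c1)C(Cl)Cl` returns only a limit of the assay, > 50000 nM, and no number. Among the values that are numbers, compound 1 stands highest of the two given, and one further entry is the limit described in the limit of > 50000 nM in this assay, at which 1 of the 3 values shown sits.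

The next compound, compound 4 `O=C(Nc1cccc(-c2ccc(Cl)cc2)c1)C(Cl)Cl`, differs from compound 1 by chloro in place of fluoro on an aromatic carbon. Going by the values given here, no measured step of this kind exists, so nothing measured fixes its size or direction. The expectation is a step of a 1.5-fold lower number from compound 1 to compound 4 (0.16 log units; within the scatter), which is within the usual scatter, with no direction asserted beyond it. Compound 4 is thus estimated at 18000 nM in this assay, with a range from 6000 nM to 48000 nM, the value yet to be seen.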

Compound 4, half-maximal inhibitory concentration: 38200 nM
Compound 4: the middle estimate sits 2.1-fold (0.33 log units) below what was measured; the range from low to high includes it.
By their numbers in this assay, from the lowest: compounds 3, 1 and 4 (each within the scatter of the next, the first and the last beyond it). At a limit, above all of these: compound 2.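

In this assay, going by these compounds alone, the first measured step reads a 1.5-fold higher number from compound 1 to compound 4 (0.16 log units; within the scatter) and gives the series its only direct comparison at this place. With chloro in place of fluoro on an aromatic carbon, para to a large group, the number stays within the scatter, so compound 1 and compound 4 are not put in any order and this exchange of one halogen for another shows no readable effect on the number. Nothing measured here speaks to the cause of this step.

From the compounds shown here alone, whether a group other than a halogen at this place, such as methoxy, an amine or a carboxylic acid, would move the number beyond the scatter stays open. Going by these compounds, compound 2 remains a limit of the assay (> 50000 nM), so how far it stands from compound 1 also stays open.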